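This account rests on a few compounds, and the source may have more. Where it says the series, first, only, none or still open, it means among the compounds named here.

Measured so far:
compound 1 `Nc1ccc2cccc(OCCC3CCCCC3)c2n1` gives 808 nM
compound 2 `CCCCCOc1cccc2ccc(N)nc12` gives 580 nM
compound 3 `CC(CC(C)(C)C)Oc1cccc2ccc(N3CCCCC3)nc12` gives > 2000 nM

Among the compounds with values here, in an assay on cells with melanin-concentrating hormone receptor 1 (Homo sapiens) as the target, read by radioligand binding (a lower number here means a stronger inhibitor, a higher number a weaker inhibitor), compound 2 and compound 1 carry the only two numbers in this set. The step of a 1.4-fold lower number from compound 1 to compound 2 (0.14 log units; within the scatter) separates them, so neither can be ranked against the other. Compound 3 sits at the limit of > 2000 nM in this assay, at which 1 of the 3 values shown sits, of this assay and gives no number. Compound 4 `Nc1ccc2cccc(OCC3CCC3)c2n1` is not yet measured. It differs from compound 2 by cyclobutyl in place of butyl on a saturated chain carbon bound to an oxygen on an aromatic ring. Within the data shown here, the one measured step that speaks to such a change is the step from compound 1 to compound 2, where a cyclohexyl gave way to a propyl two bonds along the chain from the oxygen on the aromatic ring and the number moved only within the scatter. Closing a butyl into a cyclobutyl at the chain carbon bound to that oxygen is a comparable exchange of open chain for ring of the same carbon count, so no step beyond the scatter is expected in this assay, in either direction. Compound 4 is therefore estimated at 620 nM, with a range of 300 nM to 1300 nM, which is expected to correspond to a 1.1-fold higher number from compound 2 to compound 4 (0.03 log units; within the scatter).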

Compound 4, half-maximal inhibitory concentration: 432 nM
The estimate for compound 4 lay 1.4-fold (0.16 log units) above the measured number, and the stated range covers the measured number.
By their numbers in this assay, from the lowest: compounds 4, 2 and 1 (each within the scatter of the next). At a limit, above all of these: compound 3.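

In this assay, the exchange of an open chain for a ring of the same heavy-atom count, made directly on a saturated chain carbon bound to an oxygen on an aromatic ring, gave a 1.3-fold lower number from compound 2 to compound 4 (0.13 log units; within the scatter) and so does not separate cyclobutyl from butyl at this place. The earlier step between cyclohexyl and propyl concerned a carbon two bonds along the chain from that oxygen, and it left open whether a ring set on the chain carbon bound to the oxygen would behave the same way. With this result, both steps that trade a ring for an open chain lie within the scatter, at two different places on the chain, so neither place has yet shown any preference for a ring or for an open chain.

Going by these compounds, whether a hydroxyl, an amine or a carboxylic acid on this chain, or a much shorter chain such as ethyl, would move the number beyond the scatter remains open. The data shown also offer nothing that would explain why this exchange leaves the number within the scatter.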